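Notes on the carbonyl side chain change in the series

This account rests on a few compounds, and the source may have more. Where it says the series, first, only, none or still open, it means among the compounds named here.

Measured so far:
compound 1 `Cc1c(OCCCCOc2ccc(C(=O)O)cc2)ccc(C(=O)CC2CCCC2)c1O`: 824 nM
compound 2 `Cc1c(OCCCCOCOc2ccc(C(=O)O)cc2)ccc(C(=O)CC2CCCC2)c1O`: 228 nM
compound 3 `Cc1c(OCCCCOc2ccc(C(=O)O)cc2Cl)ccc(C(=O)CC2CCCC2)c1O`: 237 nM

Compound 3 gives the second highest of the three numbers in an assay on HEK293 cells for positive allosteric modulation of metabotropic glutamate receptor 2 (Rattus norvegicus), read by thallium flux, with a stated time of 2.5 min; a lower number here means that less compound is needed, a higher number that more compound is needed for the effect. Its nearest neighbour is compound 2, and the step of a 1.0-fold higher number from compound 2 to compound 3 (0.02 log units; within the scatter) lies within the scatter, so the two cannot be ordered. The furthest is compound 1, and the step of a 3.5-fold lower number from compound 1 to compound 3 (0.54 log units; beyond the scatter) is beyond the scatter, as is the parallel step a 3.6-fold lower number from compound 1 to compound 2 (0.56 log units; beyond the scatter).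

Compound 4 `Cc1c(OCCCCOc2ccc(C(=O)O)cc2Cl)ccc(C(=O)CC(C)C)c1O` is not yet measured. It differs from compound 3 in one place: isopropyl in place of cyclopentyl on a saturated chain carbon bound to a carbonyl carbon. Neither measured step touches this part of the molecule; both alter the group on the oxygen on a saturated carbon at the far end of the chain, while the side chain bound to the carbonyl carbon is the same in compound 1, compound 2 and compound 3. Among the measured compounds shown here, there is thus no direct precedent for this change. On that basis a step of no more than modest size is anticipated, with a slight rise in the number judged somewhat more likely than a fall. For compound 4 the expected value in this assay is 450 nM, with a range from 150 nM to 1400 nM. The expected step is therefore a 1.9-fold higher number from compound 3 to compound 4 (0.28 log units; within the scatter).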

Compound 4, half-maximal effective concentration: 96 nM
For compound 4 the middle estimate is 4.7-fold (0.67 log units) above the measured one; the measured number lies below the stated range.
By their numbers in this assay, from the lowest: compound 4; then compounds 2 and 3 (each within the scatter of the next); then compound 1.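

In this assay, among the compounds shown here, the swap at the saturated chain carbon bound to a carbonyl carbon gives a 2.5-fold lower number from compound 3 to compound 4 (0.39 log units; beyond the scatter) and this is the first step at this place, so the side chain here affects the number, as the far end of the molecule did in the earlier compounds. The five-membered ring of cyclopentyl is not required on the background of compound 3: with five ring carbons leaving and the three carbons of isopropyl entering, the number does not rise. Nothing available explains why the group with fewer carbons and no ring gives the lower number, so the step stands as an observation only.

For the compounds shown here, only this one pair carries the change, so it remains open whether the same step appears without the chloro group, as on the background of compound 1, or with the (4-carboxyphenoxy)methyl end of compound 2. Also open, from the compounds shown here alone, is how the number responds to other groups at this place, such as ethyl, tert-butyl, cyclopropyl or phenyl, or to an amine within the side chain.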